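Bromoacrylamide series: methoxybenzyl in place of dimethoxyphenyl

A few compounds are considered here, and "the series" means these few. Any claim that something is new, unique, unknown or untested is made for them only; others in the source may bear on it.

Measured in a functional assay on HeLa cells (Homo sapiens) for inhibition, read by cell counting, with a stated time of 4 days; a higher number here means a weaker inhibitor, a lower number a stronger inhibitor:
compound 1 `COc1ccc(-c2nn3cc(-c4cccc(N)c4)nc3s2)cc1OC` gives 26000 nM
compound 2 `C=C(Br)C(=O)Nc1cccc(-c2cn3nc(-c4ccc(OC)c(OC)c4)sc3n2)c1` gives 610 nM
compound 3 `C=C(Br)C(=O)Nc1cccc(-c2cn3c(-c4ccccc4)csc3n2)c1` gives 3400 nM

Compound 2 holds the lowest number of the three in this assay. Its nearest neighbour is compound 3, whose number is higher, beyond the scatter; the furthest is compound 1. Going by the values given here, the only single-point step recorded is a 43-fold lower number from compound 1 to compound 2 (1.63 log units; beyond the scatter), a large drop that accompanies the (1-bromoethenyl)carbonyl entering on the ring nitrogen. Among the compounds with values here, compound 3 carries the same (1-bromoethenyl)carbonyl group on a differently arranged core and differs from compound 2 in more than one place, so its values show only that the two compounds sit apart.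

The next compound, compound 4 `C=C(Br)C(=O)Nc1cccc(-c2cn3nc(Cc4ccc(OC)cc4)sc3n2)c1`, keeps the (1-bromoethenyl)carbonyl and changes the aryl arm: 4-methoxybenzyl in place of 3,4-dimethoxyphenyl on an aromatic carbon. Within the data shown here, no measured step follows this kind of exchange, so the series gives no direct guide. The (1-bromoethenyl)carbonyl that drove a 43-fold lower number from compound 1 to compound 2 (1.63 log units; beyond the scatter) is retained, so a number in the region of compound 2 is expected, with the inserted methylene and the loss of one methoxy treated as a risk of some weakening. For compound 4 the estimate is 1500 nM, in the range 400 nM to 6000 nM, which corresponds to an expected step of a 2.5-fold higher number from compound 2 to compound 4 (0.39 log units; beyond the scatter).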

Compound 4, half-maximal inhibitory concentration: 2300 nM
Compound 4: middle estimate off by 1.5-fold (0.19 log units), on the low side, within the range that was stated.
By their numbers in this assay, from the lowest: compound 2; then compounds 4 and 3 (each within the scatter of the next); then compound 1.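

In this assay, going by these compounds alone, the aromatic carbon of the five-membered ring, next to the ring sulfur, now has a readable step of its own: with the (1-bromoethenyl)carbonyl held constant, 4-methoxybenzyl in place of 3,4-dimethoxyphenyl gives a 3.8-fold higher number from compound 2 to compound 4 (0.58 log units; beyond the scatter), a modest change at this position, whereas the only earlier step, at the ring nitrogen substituent, was large. Within the data shown here, the arm can therefore be exchanged at a measurable cost, with compound 4 still at 2300 nM, but the single step joins an inserted methylene to the loss of one methoxy and cannot assign the change to either. Nothing at hand accounts for the step.

A 4-methoxyphenyl or a 3,4-dimethoxybenzyl group on this carbon would separate the inserted methylene from the lost methoxy. Also open, as far as these compounds go, are how a longer chain or an amine on the arm would read here, and whether the (1-bromoethenyl)carbonyl carries the same weight on the 4-methoxybenzyl arm as in a 43-fold lower number from compound 1 to compound 2 (1.63 log units; beyond the scatter).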